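Shortening the thioether chain in a small antiproliferative series

A few compounds are considered here, and "the series" means these few. Any claim that something is new, unique, unknown or untested is made for them only; others in the source may bear on it.

compound 1, `CCCCSc1n[nH]c(-n2[se]c3ccccc3c2=O)n1`: 32900 nM
compound 2, `CCSc1n[nH]c(-n2[se]c3ccccc3c2=O)n1`: 14100 nM
compound 3, `CCCCCSc1n[nH]c(-n2[se]c3ccccc3c2=O)n1`: 30300 nM

These three compounds were tested in a functional assay on HeLa cells (Homo sapiens) for antiproliferative activity, read by CCK-8 assay, with a stated time of 48 h; on this read-out higher numbers stand for weaker inhibition and lower numbers for stronger inhibition. Compound 4, `CCCSc1n[nH]c(-n2[se]c3ccccc3c2=O)n1`, has not been measured; it is related to compound 3 by hydrogen in place of ethyl on a saturated chain carbon, three bonds along the chain from a sulfur. The same kind of change links compound 1 to compound 2, (hydrogen in place of ethyl on a saturated chain carbon, two bonds along the chain from a sulfur), and it produced a 2.3-fold lower number from compound 1 to compound 2 (0.37 log units; beyond the scatter). The places differ, however: the measured change sits two bonds along the chain from a sulfur, the new one three bonds along the chain from a sulfur. The two cores differ by methyl in place of hydrogen on a saturated chain carbon, four bonds along the chain from a sulfur, which gave a 1.1-fold lower number from compound 1 to compound 3 (0.04 log units; within the scatter). For compound 4 a step of a 1.4-fold lower number from compound 3 to compound 4 (0.16 log units; within the scatter) is expected, somewhat smaller than the earlier one, since the chain of compound 4 still lies between the shorter chain of compound 2 and the longer ones of compound 1 and compound 3. The estimate for compound 4 is 21000 nM, expected between 10000 nM and 42000 nM.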

Compound 4, half-maximal inhibitory concentration: 30400 nM
Compound 4: the middle estimate sits 1.4-fold (0.16 log units) below what was measured; the range from low to high includes it.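

In this assay, hydrogen in place of ethyl three bonds along the chain from the sulfur gave a 1.0-fold higher number from compound 3 to compound 4 (0.00 log units; within the scatter) and, set beside the same kind of change on the core of compound 1, the two steps cannot be told apart: the same change on two cores in this assay, a 2.3-fold lower number (0.37 log units; beyond the scatter) from compound 1 to compound 2 and a 1.0-fold higher number (0.00 log units; within the scatter) from compound 3 to compound 4, 2.3-fold (0.37 log units) apart, within the scatter of two such steps. Methyl in place of hydrogen gave a 2.2-fold higher number from compound 2 to compound 4 (0.33 log units; beyond the scatter) and hydrogen in place of methyl gave a 1.1-fold lower number from compound 1 to compound 4 (0.03 log units; within the scatter) while the methyl change also shows no difference between cores: the same change on two cores in this assay, a 1.1-fold lower number (0.04 log units; within the scatter) from compound 1 to compound 3 and a 2.2-fold higher number (0.33 log units; beyond the scatter) from compound 2 to compound 4, 2.3-fold (0.37 log units) apart, within the scatter of two such steps. This shows no measurable failure of either change to carry over, but with one pair each, one step within the scatter and one beyond it, it does not show that they transfer reliably. The compounds shown leave open whether a longer chain, or an amine or a carboxylic acid on the chain, would move the number further.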